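The source may report more compounds than this note shows. Statements on the series, on what has been measured and on what is new or still open speak of the compounds shown alone.

Measured compounds:
- compound 1, `O=C1/C(=C/c2ccc(O)cc2)CCC/C1=C\c1ccc([N+](=O)[O-])cc1`: > 400000 nM in a functional assay on HPC cells (Homo sapiens) for cytotoxicity; on this read-out higher numbers stand for lower toxicity in this test and lower numbers for higher toxicity in this test
- compound 2, `O=C1/C(=C/c2ccc(O)cc2)Cc2ccccc2/C1=C\c1ccc([N+](=O)[O-])cc1`: 113000 nM
- compound 3, `O=C1/C(=C/c2ccc(Cl)cc2)CCC/C1=C\c1ccc([N+](=O)[O-])cc1`: 345000 nM

Compound 1 reaches only a limit of this assay, (the limit of > 400000 nM in this assay, at which 1 of the 3 values shown sits). Of the two actual numbers, compound 2 gives the lowest, and compound 3 gives a higher number than compound 2, a gap that lies beyond the scatter.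

Compound 4, `COc1ccc(/C=C2\Cc3ccccc3/C(=C\c3ccc([N+](=O)[O-])cc3)C2=O)cc1OC`, has not been measured. It differs from compound 2 in one place: 3,4-dimethoxyphenyl in place of 4-hydroxyphenyl on a double-bonded chain carbon bound to a double-bonded ring carbon. Among the compounds with values here, the only measured step concerns a change on the same aromatic ring: an at least 1.1-fold lower number from compound 1 to compound 3 (0.06 log units; that floor lies within the scatter), a step whose floor lies within the scatter. That change is not the same one, so it bears on the step to compound 4 only loosely. On that basis the step from compound 2 to compound 4 is expected to be small, at most modest and toward a higher number, a 1.4-fold higher number from compound 2 to compound 4 (0.15 log units; within the scatter). Compound 4 is therefore estimated at 160000 nM, with a range from 60000 nM to 400000 nM.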

Compound 4, half-maximal cytotoxic concentration: > 400000 nM
Compound 4: a limit, no number (the forecaster's own chance of this, stated with the estimate: 20%); middle value at least 2.5-fold (0.39 log units) away from the limit.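

On the core of compound 2, 3,4-dimethoxyphenyl in place of 4-hydroxyphenyl on a double-bonded chain carbon bound to a double-bonded ring carbon gives an at least 3.5-fold higher number from compound 2 to compound 4 (0.54 log units; beyond the scatter) in this assay. This is the first change on this aromatic ring that is shown to lie beyond the scatter, whereas the earlier step, an at least 1.1-fold lower number from compound 1 to compound 3 (0.06 log units; that floor lies within the scatter), had only a floor within it. Compound 4 gives a limit and not a number, so this step too is only a floor, and its full size remains unread: the limit of > 400000 nM in this assay, at which 2 of the 4 values shown sit.

The compounds shown leave open whether the step follows from the loss of the hydroxy group or from the arrival of the two methoxy groups, as both change together. From the compounds shown here alone, how a single methoxy group or an amine on this ring would read in this assay also stays open.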